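A Fluorinated Carbamate Gives Way to an Ethylcyclopropyl Ester

The source may report more compounds than this note shows. Statements on the series, on what has been measured and on what is new or still open speak of the compounds shown alone.

Measured compounds:
compound 1, `Cc1nc(S(C)(=O)=O)ccc1Oc1ncnc(OC2CCN(C(=O)OC(C)C)CC2)c1F` — 142 nM
compound 2, `Cc1nc(S(C)(=O)=O)ccc1Oc1ncnc(OC2CCN(C(=O)O[C@@H](C)CF)CC2)c1F` — 1680 nM

In a functional assay on isolated protein for inhibition of Glucose-dependent insulinotropic receptor (Rattus norvegicus), read by HTRF and cAMP accumulation (a lower number here means that less compound is needed, a higher number that more compound is needed for the effect), compound 2 stands highest of the two numbers; its nearest neighbour is compound 1, from which it is separated by a 12-fold higher number from compound 1 to compound 2 (1.07 log units; beyond the scatter). Compound 3, `CCC1(OC(=O)N2CCC(Oc3ncnc(Oc4ccc(S(C)(=O)=O)nc4C)c3F)CC2)CC1`, differs from compound 2 by 1-ethylcyclopropyl in place of 1-(fluoromethyl)ethyl on an oxygen next to a carbonyl group. For the measured compounds named here, the single measured step that bears on this change is a 12-fold higher number from compound 1 to compound 2 (1.07 log units; beyond the scatter), which accompanied the arrival of the fluorine that compound 3 now loses, though compound 3 also carries a three-membered ring that neither measured compound has. Going by these compounds, since the fluorine leaves, the expectation is a return toward the number of compound 1, with some uncertainty because the ethylcyclopropyl group is untested. The estimated step is a 6.7-fold lower number from compound 2 to compound 3 (0.83 log units; beyond the scatter). Compound 3 is therefore expected to give 250 nM in this assay, within a range from 80 nM to 800 nM.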

Compound 3, half-maximal effective concentration: 333 nM
The estimate for compound 3 lay 1.3-fold (0.12 log units) below the measured number; the measured number falls inside the stated range.
By their numbers in this assay, from the lowest: compound 1; then compound 3; then compound 2.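

In this assay the place on an oxygen next to a carbonyl group accepts a group carrying a three-membered ring, yet 1-ethylcyclopropyl does not match isopropyl, with a 2.3-fold higher number from compound 1 to compound 3 (0.37 log units; beyond the scatter) as a modest step. Set against 1-(fluoromethyl)ethyl, the same group recovers much of the ground lost with the fluoro step, with a 5.0-fold lower number from compound 2 to compound 3 (0.70 log units; beyond the scatter) as a modest step, so the large loss seen with fluorine is not a penalty for every larger group at this place. No measurement shown gives a reason for either step.

The loss of the fluorine and the arrival of the ring fall in one step, and the compounds shown do not separate them. Going by these compounds, whether a tert-butyl or a 1-methylcyclopropyl group here would stand closer to isopropyl remains open.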